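An Ethoxy Group Enters Compound 3: What to Expect

The compounds below may be only part of what the source reports. "The series", "measured", "known", "first", "only" and "open" are said of these compounds alone.

Measured so far in a functional assay on the whole organism (blood, strain Wistar-Okamoto) with Rattus norvegicus as the target, with a stated time of 5 days; on this read-out lower numbers stand for an effect already at smaller amounts and higher numbers for an effect only at larger amounts of compound:
compound 1 `CC(/N=C(\NC#N)Nc1ccncc1)C1CC1` gives 3 mg/kg
compound 2 `CC(C)(C)N/C(=N\O)Nc1cccnc1` gives > 35 mg/kg
compound 3 `CCC(C)(C)N/C(=N\C#N)Nc1ccccc1` gives 50 mg/kg

Compound 2 stands at a limit of the assay: the limit of > 35 mg/kg in this assay, at which 1 of the 3 values shown sits, so it gives no number. Of the two numbers, compound 3 holds the higher one, compound 1 the lower, a gap beyond the scatter of this assay.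

Compound 4 `CCOc1ccccc1N/C(=N/C#N)NC(C)(C)CC` differs from compound 3 in one place: ethoxy in place of hydrogen on an aromatic carbon. Going by the values given here, no measured pair shows what such an added group does here, so the expected step of a 1.4-fold lower number from compound 3 to compound 4 (0.15 log units; within the scatter) is one within the scatter, in no particular direction.

For compound 4 in this assay the estimate is 35 mg/kg, expected between 10 mg/kg and 120 mg/kg.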

Compound 4, minimum effective dose: 20 mg/kg
The estimate for compound 4 lay 1.8-fold (0.24 log units) above the measured number, within the range that was stated.
By their numbers in this assay, from the lowest: compound 1; then compound 4; then compound 3.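

In this assay, going by these compounds alone, the one pair of compounds that differ in one place gives a 2.5-fold lower number from compound 3 to compound 4 (0.40 log units; beyond the scatter). So ethoxy in place of hydrogen on this aromatic carbon, ortho to a large group, does not cost activity, and the number moves modestly downward, a shift that lies beyond the scatter. Nothing measured here says why the number moves.

As far as these compounds go, whether methoxy, an amine or a longer chain on the same carbon would move the number the same way stays open. So does whether ethoxy would act alike on the core of compound 1.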